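The source may hold more compounds than are shown below. What is called first, only, known or untested is meant among the compounds shown, and "the series" means these compounds.

Compound 2 `CCCCOc1ccc2c(Cl)ccnc2c1` is one of two ethers of the shared core measured in a functional assay on HCT-116 cells (Homo sapiens) for cytotoxicity, read by MTT assay, with a stated time of 48 h; a higher number here means a weaker inhibitor, a lower number a stronger inhibitor. In this assay compound 2 gives 2740 nM, the higher of the two numbers. Its neighbour is compound 1 `CC(C)COc1ccc2c(Cl)ccnc2c1`, which in this assay gives 2490 nM; the step of a 1.1-fold higher number from compound 1 to compound 2 (0.04 log units; within the scatter) lies within the scatter, so the two compounds are not separated on this read-out.

Compound 3 `CCCCCCCCOc1ccc2c(Cl)ccnc2c1` extends the chain of compound 2: butyl in place of hydrogen on a saturated chain carbon, four bonds along the chain from an oxygen on an aromatic ring. Among the measured compounds shown here, the only measured step, a 1.1-fold higher number from compound 1 to compound 2 (0.04 log units; within the scatter), is a rearrangement within the chain rather than a lengthening, and it carried no change beyond the scatter; no step in the set adds carbon to the chain. The expectation for compound 3 is therefore a step of a 1.2-fold lower number from compound 2 to compound 3 (0.10 log units; within the scatter), with no direction supported beyond the scatter and a wide range. Compound 3 is estimated at 2200 nM in this assay, between 700 nM and 7000 nM.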

Compound 3, half-maximal inhibitory concentration: 2820 nM
For compound 3 the middle estimate is 1.3-fold (0.11 log units) below the measured one, and the stated range covers the measured number.
By their numbers in this assay, from the lowest: compounds 1, 2 and 3 (each within the scatter of the next).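

In this assay, among the compounds shown here, butyl in place of hydrogen on a saturated chain carbon, four bonds along the chain from an oxygen on an aromatic ring, gives the first step that adds carbon to the chain (a 1.0-fold higher number from compound 2 to compound 3 (0.01 log units; within the scatter)). This position therefore accepts butyl without separating compound 2 from compound 3 on this read-out, whereas the earlier pair tested only a rearrangement within the chain. No measurement available here accounts for this lack of separation.

Open, from the compounds shown here alone, is whether a longer chain, an amine or a carboxylic acid at this position would give a step beyond the scatter. Going by these compounds, with a single cell read-out, it also remains open whether compound 2 and compound 3 differ in any other measure.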